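The compounds below may be only part of what the source reports. "The series", "measured", "known", "first", "only" and "open" are said of these compounds alone.

Working notes on the sulfonamide series in an assay on cells for inhibition of HSP60/HSP10 (Homo sapiens), with a stated time of 60 min; a higher number here means a weaker inhibitor, a lower number a stronger inhibitor.

Compound 1 `Cc1ccc(S(=O)(=O)Nc2ccc3oc(-c4ccccc4)nc3c2)cc1` is reported in this assay only as a limit, > 100000 nM, as noted in the limit of > 100000 nM in this assay, at which 1 of the 3 values shown sits. Compound 2 `O=S(=O)(Nc1ccc(-c2nc3ccccc3o2)cc1)c1cccc(Cl)c1` gives 54000 nM, and compound 3 `O=S(=O)(Nc1ccc(-c2nc3ccccc3o2)cc1)c1cccc(C(F)(F)F)c1` gives 57000 nM; these two lie within the scatter of each other, so compound 2 is neither distinguished from nor ordered against compound 3. Among the measured compounds shown here, the sole measured step, a 1.1-fold higher number from compound 2 to compound 3 (0.02 log units; within the scatter), is within the scatter.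

Compound 4 `COc1ccc(S(=O)(=O)Nc2ccc(-c3nc4ccccc4o3)cc2)cc1` carries 4-methoxyphenyl in place of 3-chlorophenyl on a sulfonyl sulfur. For the measured compounds named here, no measured step touches a methoxy group; the one step on the same sulfonyl sulfur was flat, so the expected step of a 1.3-fold higher number from compound 2 to compound 4 (0.11 log units; within the scatter) is none beyond the scatter, with a real chance of a limit. Compound 4 is estimated at 70000 nM, range 30000 nM to 200000 nM.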

Compound 4, half-maximal inhibitory concentration: > 100000 nM
Compound 4: only a limit was reported; the forecaster's own chance of this, stated with the estimate: 30%; middle value at least 1.4-fold (0.15 log units) away from the limit.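

Compound 4 is reported only as a limit, and an at least 1.8-fold higher number from compound 2 to compound 4 (0.26 log units; that floor lies within the scatter) is all that can be read of this change on the sulfonyl sulfur. That floor does not separate 4-methoxyphenyl from 3-chlorophenyl, so the position is still not shown to respond to substitution. Unlike the earlier change at this position, however, this one leaves a second compound at the limit: the limit of > 100000 nM in this assay, at which 2 of the 4 values shown sit.

The compounds shown do not separate the methoxy group from its position in 4-methoxyphenyl. As far as these compounds go, what an amine or a carboxylic acid on this ring would do remains open.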